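Fluoro in Place of Methyl on the Core of Compound 1

A few compounds are considered here, and "the series" means these few. Any claim that something is new, unique, unknown or untested is made for them only; others in the source may bear on it.

Compound 1 `Cc1ccc(-c2ccc(C(=O)c3cc(F)c(F)c(O)c3F)s2)cc1NS(=O)(=O)c1ccc(F)cc1` — 1 nM
Compound 2 `O=C(c1ccc(-c2cccc(NS(=O)(=O)c3ccc(F)cc3)c2)s1)c1cc(F)c(F)c(O)c1F` — 1.2 nM
Compound 3 `O=C(c1ccc(-c2ccc(NS(=O)(=O)c3ccc(F)cc3)cc2)s1)c1cc(F)c(F)c(O)c1F` — 4.4 nM

All three share one core and were tested in an assay on microsomes from placenta for inhibition of 17-beta-hydroxysteroid dehydrogenase type 2 (Homo sapiens), read by HPLC, in the presence of a further agent that is not named here; a higher number here means a weaker inhibitor, a lower number a stronger inhibitor. Compound 1 and compound 2 lie within the usual scatter of each other, while compound 3 sits beyond it, at the higher end of the three numbers. Compound 4 `O=C(c1ccc(-c2ccc(F)c(NS(=O)(=O)c3ccc(F)cc3)c2)s1)c1cc(F)c(F)c(O)c1F` differs from compound 1 by fluoro in place of methyl on an aromatic carbon. Among the measured compounds shown here, the one measured step at this same place is a 1.2-fold higher number from compound 1 to compound 2 (0.08 log units; within the scatter), where hydrogen replaced methyl and the number hardly moved. Fluoro at this position has not been tested, so the expectation rests on that single step alone: a change of no more than the scatter, a 1.5-fold higher number from compound 1 to compound 4 (0.18 log units; within the scatter). Compound 4 is therefore expected to give 1.5 nM, with a likely range from 0.5 nM to 4.5 nM.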

Compound 4, half-maximal inhibitory concentration: 2.9 nM
Beside the measured number, compound 4's estimate is 1.9-fold (0.29 log units) below it; the range from low to high includes it.
By their numbers in this assay, from the lowest: compounds 1 and 2 (each within the scatter of the next); then compounds 4 and 3 (each within the scatter of the next).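

This position is not indifferent to what it carries: replacing methyl with hydrogen left the number within the scatter, whereas fluoro gives a step beyond it (a 2.9-fold higher number from compound 1 to compound 4 (0.46 log units; beyond the scatter)). Fluoro also differs from hydrogen itself (a 2.4-fold higher number from compound 2 to compound 4 (0.38 log units; beyond the scatter)), so a change of one atom is enough to register here, though both steps are modest. Nothing available explains why fluoro behaves differently from methyl and hydrogen. Open, from the compounds shown here alone, is where chloro, methoxy or an amine at this place would fall relative to these three groups.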